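A New Aromatic Group on a Series Stuck at a Limit

A few compounds are considered here, and "the series" means these few. Any claim that something is new, unique, unknown or untested is made for them only; others in the source may bear on it.

Compound 1 (`C/C(=N\NC(=O)c1cccc(S(=O)(=O)N2CCOCC2)c1)c1cccc(N)c1`), compound 2 (`C/C(=N\NC(=O)c1cccc(S(=O)(=O)N2CCOCC2)c1)c1ccc(F)cc1`) and compound 3 (`C/C(=N\NC(=O)c1cccc(S(=O)(=O)N2CCOCC2)c1)c1cccc(O)c1`) share one core and differ only in the aromatic group on a carbon with a double bond to nitrogen. In a functional assay on MGC-803 cells (Homo sapiens) for antiproliferative activity, read by MTT assay, with a stated time of 72 h (a higher number here means a weaker inhibitor, a lower number a stronger inhibitor), compound 1 gives > 100000 nM, which is a limit and not a number. Compound 2 gives > 100000 nM, also a limit. Compound 3 gives > 100000 nM, again a limit. Compound 3 therefore stands with the other two, as the limit of > 100000 nM in this assay, at which 3 of the 3 values shown sit, shows.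

Compound 4 (`C/C(=N\NC(=O)c1cccc(S(=O)(=O)N2CCOCC2)c1)c1cc(Br)ccc1O`) changes one group of compound 3: 5-bromo-2-hydroxyphenyl in place of 3-hydroxyphenyl on a carbon with a double bond to nitrogen. For the measured compounds named here, three measured steps bear on this change: a step that the two limits leave unreadable from compound 1 to compound 2, a step that the two limits leave unreadable from compound 1 to compound 3 and a step that the two limits leave unreadable from compound 2 to compound 3. None of them has a size that can be carried over, and none involves the group that enters here.

Compound 3 sits at > 100000 nM, a limit, so the only readable movement open is downward, towards stronger inhibition in this assay. Compound 4 may also remain at the limit. The expected change is an at least 10-fold lower number from compound 3 to compound 4 (1.00 log units; beyond the scatter), and its size is highly uncertain. For compound 4, the estimated value is 10000 nM, with an expected range from 1500 nM to 70000 nM.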

Compound 4, half-maximal inhibitory concentration: 18000 nM
Compound 4: middle estimate off by 1.8-fold (0.26 log units), on the low side; low and high end bracket the measured number.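

In this assay, the 5-bromo-2-hydroxyphenyl group is the only one shown on this carbon with a double bond to nitrogen that gives a compound a measured number and not a limit, with an at least 5.5-fold lower number from compound 3 to compound 4 (0.74 log units; beyond the scatter), an at least 5.5-fold lower number from compound 2 to compound 4 (0.74 log units; beyond the scatter) and an at least 5.5-fold lower number from compound 1 to compound 4 (0.74 log units; beyond the scatter). The steps among compound 1, compound 2 and compound 3 cannot be read, which left no sign that the group at this place could change the result at all; the new steps now show that it can. Each new step is a minimum and not a full size, and compound 4 alone stands apart from the shared limit: the limit of > 100000 nM in this assay, at which 3 of the 4 values shown sit.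

The change from 3-hydroxyphenyl to 5-bromo-2-hydroxyphenyl adds a bromine and also alters where the hydroxy sits, and the compounds shown do not separate these two changes. A plain 2-hydroxyphenyl group would test the hydroxy alone, and a 5-chloro-2-hydroxyphenyl group would test whether another halogen can take the place of the bromine.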